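Tert-butyl in place of bromo: expected rise in inhibition

The source may report more compounds than this note shows. Statements on the series, on what has been measured and on what is new or still open speak of the compounds shown alone.

In a functional assay on A549 cells (Homo sapiens) for inhibition, read by CCK-8 assay, with a stated time of 72 h, tested at 8 uM (on this read-out higher numbers stand for more inhibition of growth at the one concentration tested and lower numbers for less inhibition of growth), compound 3 (`Nc1ccccc1NC(=O)c1ccc(CSc2ccc(Br)cc2)cc1`) gives 45.7% and stands lowest of the three measured compounds, beyond the scatter from both others. Compound 1 (`COc1ccc(SCc2ccc(C(=O)Nc3ccccc3N)cc2)cc1`) gives 70.7% in the same read-out, and compound 2 (`CCc1ccc(SCc2ccc(C(=O)Nc3ccccc3N)cc2)cc1`) gives 91.4% there. Compound 4 (`CC(C)(C)c1ccc(SCc2ccc(C(=O)Nc3ccccc3N)cc2)cc1`), still unmeasured, differs from compound 3 by tert-butyl in place of bromo on an aromatic carbon.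

For the measured compounds named here, three measured steps bear on this place. The largest is a number 45.7 percentage points lower from compound 2 to compound 3 (beyond the scatter) for bromo in place of ethyl. Bromo in place of methoxy gives a number 25 percentage points lower from compound 1 to compound 3 (beyond the scatter) in the same direction, and ethyl in place of methoxy gives a number 20.7 percentage points higher from compound 1 to compound 2 (beyond the scatter) as well. Ethyl, in compound 2, is the nearest measured group to tert-butyl, but tert-butyl itself is untested. A rise beyond the scatter, modest to large, is therefore expected in this assay on leaving bromo. The expected move is a number 32.3 percentage points higher from compound 3 to compound 4 (beyond the scatter) as an estimate. For compound 4 the estimated value is 78% within a range of 58% to 96% as expected bounds.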

Compound 4, percent growth inhibition at one concentration: 67%
Compound 4: middle estimate off by 11 percentage points, on the high side; low and high end bracket the measured number.
By their numbers in this assay, from the lowest: compound 3; then compounds 4 and 1 (each within the scatter of the next); then compound 2.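

In this assay, tert-butyl improves on bromo (a number 21.3 percentage points higher from compound 3 to compound 4 (beyond the scatter)) but does not reach the level seen with ethyl (a number 24.4 percentage points lower from compound 2 to compound 4 (beyond the scatter)), so moving from ethyl to the larger alkyl group does not preserve the result of compound 2. Against methoxy, the change is a number 3.7 percentage points lower from compound 1 to compound 4 (within the scatter), so tert-butyl and methoxy cannot be told apart here, while ethyl and bromo each stand beyond the scatter from all three other groups at this place. Nothing measured here explains these differences.

The compounds shown leave open how an isopropyl group, an amine or a carboxylic acid would read at this place. They also leave open whether the order among these four compounds holds at other concentrations or in other cell lines.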